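The source may hold more compounds than are shown below. What is called first, only, known or untested is meant among the compounds shown, and "the series" means these compounds.

Compound 1 `O=C(CCN1C(=O)CSc2ccccc21)N1CCN(c2ccc(C(F)(F)F)cc2)CC1` and compound 3 `O=C(CCN1C(=O)CSc2ccccc21)NCCCN1CCN(c2ccc(C(F)(F)F)cc2)CC1` were both tested in a functional assay on IMR-32 cells (Homo sapiens) for inhibition, read by sulforhodamine B assay, with a stated time of 48 h; on this read-out higher numbers stand for weaker inhibition of growth and lower numbers for stronger inhibition of growth. In this assay compound 1 gives 46400 nM. Compound 3 gives 1400 nM in this assay, the lower of the two numbers. The difference between the core of compound 1 and the core of compound 3 is not broken down here. Compound 2 `O=C(CCN1C(=O)CSc2ccccc21)N1CCN(c2ccccc2F)CC1` carries the change 2-fluorophenyl in place of 4-(trifluoromethyl)phenyl on an amine nitrogen in a ring relative to compound 1. In this assay compound 2 reaches only a limit, > 100000 nM. The step of an at least 2.1-fold higher number from compound 1 to compound 2 (0.33 log units; beyond the scatter) therefore rests on the limit (the limit of > 100000 nM in this assay, at which 1 of the 3 values shown sits), so its full size is not known. Compound 4 `O=C(CCN1C(=O)CSc2ccccc21)NCCCN1CCN(c2ccccc2F)CC1` is not yet measured; it differs from compound 3 by 2-fluorophenyl in place of 4-(trifluoromethyl)phenyl on an amine nitrogen in a ring, the same change as made from compound 1 to compound 2, at a place described in the same words. Because of the step of an at least 2.1-fold higher number from compound 1 to compound 2 (0.33 log units; beyond the scatter), compound 4 is expected to show a weaker result than its parent, estimated as a 4.3-fold higher number from compound 3 to compound 4 (0.63 log units; beyond the scatter). The estimate for compound 4 in this assay is 6000 nM, expected to fall between 2000 nM and 30000 nM.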

Compound 4, concentration for 50% growth inhibition: 1400 nM
Compound 4: middle estimate off by 4.3-fold (0.63 log units), on the high side; measured number below the stated range.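

In this assay, putting 2-fluorophenyl in place of 4-(trifluoromethyl)phenyl on the core of compound 3 gives no change at the digits printed from compound 3 to compound 4 (within the scatter), so on this core the change leaves the growth-inhibition number where it stands. Set beside the same change on the core of compound 1, the comparison reads: the same change on two cores in this assay, an at least 2.1-fold higher number (0.33 log units; beyond the scatter) from compound 1 to compound 2 and no change at the digits printed (within the scatter) from compound 3 to compound 4; the limit leaves it open whether they differ. Going by these compounds, compound 2 sits at a limit, > 100000 nM, so the size of the earlier step is unknown, and these two pairs show neither that the change acts differently on the two cores nor that it acts alike on them.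

The compounds shown leave open whether other groups on the same amine nitrogen, such as an unsubstituted phenyl or 4-fluorophenyl, would also give matching numbers on the core of compound 3. They also leave open whether a longer chain in that core would alter the effect of this change, and whether the pattern holds in cells other than those of this single assay.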